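Replacing cyclohexyl with 3,4-dichlorophenyl on an amide-type nitrogen

This account rests on a few compounds, and the source may have more. Where it says the series, first, only, none or still open, it means among the compounds named here.

Measured in a functional assay on MGC-803 cells (Homo sapiens) for antiproliferative activity, read by MTT assay, with a stated time of 48 h; a higher number here means a weaker inhibitor, a lower number a stronger inhibitor:
Compound 1 `O=C(Nc1ccc(Cl)cc1)Nc1cccc(CNc2nccnc2Cl)c1`: 4980 nM
Compound 2 `CN(C)c1ccc(NC(=O)Nc2cccc(CNc3nccnc3Cl)c2)cc1`: 11500 nM
Compound 3 `O=C(Nc1cccc(CNc2nccnc2Cl)c1)NC1CCCCC1`: > 40000 nM

In this assay compound 3 stands at > 40000 nM, which is a limit of the assay and not a number. The set holds one such case (the limit of > 40000 nM in this assay, at which 1 of the 3 values shown sits). Compound 4 `O=C(Nc1cccc(CNc2nccnc2Cl)c1)Nc1ccc(Cl)c(Cl)c1` has not yet been measured. It carries 3,4-dichlorophenyl in place of cyclohexyl on an amide-type nitrogen.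

Among the compounds with values here, two measured steps bear on this change, and both run the opposite way. Cyclohexyl in place of 4-chlorophenyl gave an at least 8.0-fold higher number from compound 1 to compound 3 (0.90 log units; beyond the scatter), and cyclohexyl in place of 4-(dimethylamino)phenyl gave an at least 3.4-fold higher number from compound 2 to compound 3 (0.54 log units; beyond the scatter). Both lie beyond the scatter. Among the two compounds with an aromatic group here, the step of a 2.3-fold higher number from compound 1 to compound 2 (0.36 log units; beyond the scatter) leaves the chloro-bearing compound 1 with the lower number. Compound 1 (4980 nM) is also the nearest measured relative of compound 4, so a return from cyclohexyl to a chlorinated aromatic group is expected to lower the number by at least a modest step. As far as these compounds go, the estimate means an at least 11-fold lower number from compound 3 to compound 4 (1.05 log units; beyond the scatter), an expected step whose true size stays open while compound 3 has only a limit. Compound 4 is expected at about 3500 nM, within an estimated range from 1200 nM to 11000 nM.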

Compound 4, half-maximal inhibitory concentration: 4970 nM
For compound 4 the middle estimate is 1.4-fold (0.15 log units) below the measured one; the range from low to high includes it.
By their numbers in this assay, from the lowest: compounds 4 and 1 (each within the scatter of the next); then compound 2. At a limit, above all of these: compound 3.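

In this assay, 3,4-dichlorophenyl in place of cyclohexyl on the amide-type nitrogen gives an at least 8.0-fold lower number from compound 3 to compound 4 (0.90 log units; beyond the scatter), the first direct reading of this change, though its size remains a bound and compound 3 is a limit of the assay and not a number: the limit of > 40000 nM in this assay, at which 1 of the 4 values shown sits.

The added chloro on the aromatic ring brings no measurable change, with chloro in place of hydrogen on an aromatic carbon giving a 1.0-fold lower number from compound 1 to compound 4 (0.00 log units; within the scatter), so compound 4 and compound 1 cannot be told apart in this assay. Against the dimethylamino-bearing partner, the change to 3,4-dichlorophenyl gives a 2.3-fold lower number from compound 2 to compound 4 (0.36 log units; beyond the scatter), so in the three compounds with an aromatic group here, the two that carry chloro share the lower level and compound 2 stands apart from them.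

Whether the aromatic ring needs chloro at all stays open, as the compounds shown include no plain phenyl, nor a phenyl bearing methoxy or a carboxylic acid. All of them also keep the shared core unchanged, so they leave open how much the chloro on that core contributes, and how far compound 3 truly lies from the others.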